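Porcupine series: removing the fluoro from compound 3

A few compounds are considered here, and "the series" means these few. Any claim that something is new, unique, unknown or untested is made for them only; others in the source may bear on it.

Measured compounds
compound 1 `COc1ccc(-n2nc(C(=O)NCC(=O)Nc3nc4ccccc4s3)c3ccccc3c2=O)cc1` — 25000 nM
compound 2 `O=C(CNC(=O)c1nn(-c2ccccc2)c(=O)c2ccccc12)Nc1nc2ccc(Cl)cc2s1` — 30 nM
compound 3 `O=C(CNC(=O)c1nn(-c2ccc(F)cc2)c(=O)c2ccccc12)Nc1nc2ccccc2s1` — > 25000 nM

All values come from an assay on L cells for inhibition of Protein-serine O-palmitoleoyltransferase porcupine (Mus musculus), read by reporter gene assay, with a stated time of 24 h; on this read-out higher numbers stand for an effect only at larger amounts of compound and lower numbers for an effect already at smaller amounts. Compound 3 gives only a limit of the assay, > 25000 nM, so it stands at the weak end of the numbers shown. Among the measured compounds shown here, the one step measured in one place is a number no lower from compound 1 to compound 3 (the limit leaves the size open); both compounds with a substituent on that carbon sit at the weak end, and the limit of > 25000 nM in this assay, at which 1 of the 3 values shown sits, leaves the size of the step open. Compound 2 shares the unsubstituted phenyl with compound 4 but differs elsewhere, and its value in this assay is much lower than that of compound 1.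

Compound 4 `O=C(CNC(=O)c1nn(-c2ccccc2)c(=O)c2ccccc12)Nc1nc2ccccc2s1` differs from compound 3 by hydrogen in place of fluoro on an aromatic carbon. For the measured compounds named here, no measured step covers this change directly. Compound 4 is therefore estimated at 1500 nM, within 100 nM to 25000 nM. The expected step is an at least 16-fold lower number from compound 3 to compound 4 (1.22 log units; beyond the scatter), a gain beyond the scatter but of uncertain size.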

Compound 4, half-maximal effective concentration: 2600 nM
Beside the measured number, compound 4's estimate is 1.7-fold (0.24 log units) below it; the measured number falls inside the stated range.
By their numbers in this assay, from the lowest: compound 2; then compound 4; then compound 1.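

In this assay hydrogen in place of fluoro gives an at least 9.6-fold lower number from compound 3 to compound 4 (0.98 log units; beyond the scatter) and hydrogen in place of methoxy on the same carbon gives a 9.6-fold lower number from compound 1 to compound 4 (0.98 log units; beyond the scatter) on the shared core, so the unsubstituted phenyl of compound 4 is the better of the three at this position. On these data alone, the value of compound 3 is a limit, so the fluoro step has only a lower bound and its true size stays open: the limit of > 25000 nM in this assay, at which 1 of the 4 values shown sits. Elsewhere in the molecule, hydrogen in place of chloro gives an 87-fold higher number from compound 2 to compound 4 (1.94 log units; beyond the scatter) and shows that compound 4 does not mark the low end of the numbers in this series.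

Only fluoro and methoxy are shown on this carbon, so whether a methyl or an amine there would also go with a weak value stays open. Also open, as far as these compounds go, is whether the chloro of compound 2 would keep its gain with fluoro on the phenyl.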